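Swapping 5-fluoropyridin-2-yl for 1,3-thiazol-2-yl

A few compounds are considered here, and "the series" means these few. Any claim that something is new, unique, unknown or untested is made for them only; others in the source may bear on it.

Compound 2 `O=S(=O)(Nc1nccs1)c1ccc2c(c1)OCC[C@@H]2c1ccc(C(F)(F)F)cc1-c1ccc(F)cn1` gives 3.5 in a physicochemical assay for lipophilicity (a higher number here means a more lipophilic compound, a lower number a more polar compound), and compound 1 `O=S(=O)(Nc1nccs1)c1ccc2c(c1)OCC[C@H]2c1ccc(C(F)(F)F)cc1-c1nccs1` gives 3.3 in the same measurement, so the two stand within the scatter of each other. Compound 3 `O=S(=O)(Nc1nccs1)c1ccc2c(c1)OCC[C@@H]2c1ccc(C(F)(F)F)cc1-c1nccs1` has not yet been measured. It departs from compound 2 by a single change (1,3-thiazol-2-yl in place of 5-fluoropyridin-2-yl on an aromatic carbon) 1,3-thiazol-2-yl in place of 5-fluoropyridin-2-yl on an aromatic carbon at a place ortho to a large group and meta to a trifluoromethyl group. Within the data shown here, no measured pair isolates this change. The closest guide is compound 1, which carries the same 1,3-thiazol-2-yl group and gives 3.3 as its reading. The expected result is a number 0.20 log units lower from compound 2 to compound 3 (within the scatter) as a slight fall at most, not beyond the scatter. Compound 3 is estimated at 3.3 with a range of 3.1 to 3.5 expected.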

Compound 3, distribution coefficient: 3.3
Compound 3: the middle estimate sits on the measured number at the digits printed; low and high end bracket the measured number.
By their numbers in this assay, from the lowest: compounds 1, 3 and 2 (each within the scatter of the next).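

In this assay, the exchange of 5-fluoropyridin-2-yl for 1,3-thiazol-2-yl on an aromatic carbon, ortho to a large group and meta to a trifluoromethyl group, now has a pair that isolates it, and that pair shows a number 0.20 log units lower from compound 2 to compound 3 (within the scatter). A second pair isolates the stereocentre at a saturated ring carbon and shows no change at the digits printed from compound 1 to compound 3 (within the scatter), a comparison that involves nothing else: the fact that compounds 1 and 3 differ only in the configuration as drawn. Among these three compounds, neither the ring exchange nor the configuration as drawn separates any pair beyond the scatter.

The compounds shown carry only these two aromatic rings at this position, so it remains open how an amine or a carboxylic acid there would read in this assay. On these data alone, it also remains open whether configuration would separate a pair carrying 5-fluoropyridin-2-yl.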